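Swapping a Halogenated Phenyl on a Non-Toxic Core

The compounds below may be only part of what the source reports. "The series", "measured", "known", "first", "only" and "open" are said of these compounds alone.

Of the compounds shown here, three sharing one core have been tested in an ADME assay on Vero cells (Chlorocebus sabaeus) for cytotoxicity, read by XTT assay, with a stated time of 72 h; a higher number here means that more compound is tolerated, a lower number that less compound is tolerated. Compound 1 `CC1=C(C(=O)Nc2ccc(Br)cc2)C(c2ccccc2)NC(=O)N1` gives > 100000 nM in this assay, a limit rather than a number. For compound 1 that reading, (the limit of > 100000 nM in this assay, at which 1 of the 3 values shown sits), is the only figure across the set. Compound 2 `CC1=C(C(=O)Nc2ccccc2Cl)C(c2ccccc2Cl)NC(=O)N1` is recorded as "non-toxic" (no number reported) in this assay. Compound 3 `CC1=C(C(=O)Nc2ccccc2Cl)C(c2ccc(Cl)cc2)NC(=O)N1` is recorded as "non-toxic" (no number reported) in this assay, so no single number places it on a scale. Compound 4 `CC1=C(C(=O)Nc2ccccc2Cl)C(c2cccc(Br)c2)NC(=O)N1` carries 3-bromophenyl in place of 4-chlorophenyl on a saturated ring carbon. With no measured step between any two of these compounds, no change beyond the usual scatter is expected in this assay. Compound 4 is therefore expected to sit near 100000 nM, within a range from 50000 nM to 200000 nM, most likely reported again as a limit.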

Compound 4, half-maximal cytotoxic concentration: > 100000 nM
Compound 4 gave a limit, no number; the forecaster's own chance of this, stated with the estimate: 80%; the middle value sits exactly at the limit.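

Compound 4 gives > 100000 nM, a limit and not a number. Among the compounds shown here, compound 3 is recorded only as non-toxic, so no step between compound 3 and compound 4 can be read. The compounds shown leave open at what concentration any of them harms these cells.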